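A few compounds are considered here, and "the series" means these few. Any claim that something is new, unique, unknown or untested is made for them only; others in the source may bear on it.

Measured compounds:
- Compound 1 `Cc1cc(C#N)cc(C)c1Oc1nc(Nc2ccc(C#N)cc2)ncc1-c1ccccc1` gives 31800 nM in an ADME assay on MT4 cells (Homo sapiens) for cytotoxicity, read by MTT assay, with a stated time of 5 days; on this read-out lower numbers stand for higher toxicity in this test and higher numbers for lower toxicity in this test.
- Compound 2 `Cc1cc(C#N)cc(C)c1Oc1nc(Nc2ccc(C#N)cc2)ncc1-c1ccsc1` gives 3920 nM in this assay.

Going by the values given here, compound 1 stands at the highest of the two numbers in this assay; its nearest neighbour is compound 2, and the single step between them, an 8.1-fold lower number from compound 1 to compound 2 (0.91 log units; beyond the scatter), is a change of the aromatic ring itself. Compound 3 `Cc1cc(C#N)cc(C)c1Oc1nc(Nc2ccc(C#N)cc2)ncc1-c1ccc(F)cc1` differs from compound 1 only by fluoro in place of hydrogen on an aromatic carbon. Among the compounds with values here, that step is of another kind than the one measured: no compound in this set tests fluoro against hydrogen on this ring, so the measured step does not bear directly on it, and the ring swap to thiophen-3-yl gives no guide to how a single fluorine on the retained phenyl will read. With nothing shown to the contrary, the expectation is that compound 3 stays close to compound 1, with no step beyond the scatter, so that a 1.3-fold lower number from compound 1 to compound 3 (0.10 log units; within the scatter) is expected to be small. Compound 3 is therefore estimated at 25000 nM in this assay, with a range from 9000 nM to 60000 nM.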

Compound 3, half-maximal cytotoxic concentration: 42700 nM
The estimate for compound 3 lay 1.7-fold (0.23 log units) below the measured number, and the stated range covers the measured number.
By their numbers in this assay, from the lowest: compound 2; then compounds 1 and 3 (each within the scatter of the next).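

In this assay, going by these compounds alone, the step of a 1.3-fold higher number from compound 1 to compound 3 (0.13 log units; within the scatter) shows that, at this place on the phenyl ring, para to a large group, fluoro in place of hydrogen leaves the number within the scatter, so this single atom is the first change here that does not separate two compounds. The step of an 11-fold higher number from compound 2 to compound 3 (1.04 log units; beyond the scatter) is larger and lies beyond the scatter, which shows that the lower number of compound 2 is not matched by the 4-fluorophenyl compound; among these three compounds, only the one with thiophen-3-yl stands apart, and compounds 1 and 3 stay together. Nothing in the information available accounts for either the closeness of compounds 1 and 3 or the distance of compound 2 from compound 3.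

On these data alone, it remains open whether another group at this same place, such as chloro, methoxy, an amine or a carboxylic acid, would also stay within the scatter of compound 1, or whether fluoro elsewhere on the phenyl ring would read the same. As far as these compounds go, it is equally open whether thiophen-2-yl or furan-3-yl would give a number like that of compound 2 or one like those of compounds 1 and 3.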